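The source may report more compounds than this note shows. Statements on the series, on what has been measured and on what is new or still open speak of the compounds shown alone.

Measured compounds:
- compound 1, `CC1CCCCN1C(=S)SCc1ccc(C(=O)Nc2ccccc2N)cc1`: 64.4%
- compound 2, `Nc1ccccc1NC(=O)c1ccc(CSC(=S)N2CCc3ccc([N+](=O)[O-])cc32)cc1`: 30.6%
- compound 3, `Nc1ccccc1NC(=O)c1ccc(CSC(=S)N2CCN(Cc3ccncc3)CC2)cc1`: 18.4%

The three measured compounds share a core and differ only in the amine attached to the thiocarbonyl carbon. In a functional assay on MGC-803 cells (Homo sapiens) for antiproliferative activity, read by CCK-8 assay, with a stated time of 72 h, tested at 2 uM (on this read-out higher numbers stand for a stronger effect at the one concentration tested and lower numbers for a weaker effect), compound 1 gives 64.4%, the highest of the three numbers. Compound 2 gives 30.6%, and compound 3 gives 18.4%; both gaps to compound 1 lie beyond the scatter, so compound 1 stands clearly ahead on these numbers.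

Compound 4, `Nc1ccccc1NC(=O)c1ccc(CSC(=S)N2CCCc3ccccc32)cc1`, has not yet been measured. It differs from compound 1 in one place: 1,2,3,4-tetrahydroquinolin-1-yl in place of 2-methylpiperidin-1-yl on a thiocarbonyl carbon. The two measured compounds that carry a different amine than compound 1 both fall short of it, which suggests that replacing the 2-methylpiperidin-1-yl group costs activity in this set. A step from compound 1 to compound 4 in this assay is therefore expected to be downward, of modest size and possibly within the scatter, as expressed by a number 14.4 percentage points lower from compound 1 to compound 4 (beyond the scatter). Compound 4 is estimated to give 50%, within a range from 25% to 75%.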

Compound 4, a percentage reported as inhibition, at one concentration (the size of the read-out at that concentration, not a potency): 38.5%
Compound 4: middle estimate off by 11.5 percentage points, on the high side; the measured number falls inside the stated range.
By their numbers in this assay, from the lowest: compound 3; then compounds 2 and 4 (each within the scatter of the next); then compound 1.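

In this assay, among these compounds, this is the first step in the set that can be read as a single change on the thiocarbonyl carbon: 1,2,3,4-tetrahydroquinolin-1-yl in place of 2-methylpiperidin-1-yl gives a number 25.9 percentage points lower from compound 1 to compound 4 (beyond the scatter). The entering group keeps a six-membered non-aromatic ring with 1 hetero atom and adds a six-membered aromatic ring of carbon only, while neither group has hydrogen-bond donors, hydrogen-bond acceptors or a net charge, so the loss appears with those counts unchanged. No measurement that could explain the drop is at hand.

The compounds shown do not separate the loss of the methyl group from the gain of the aromatic ring. As far as these compounds go, how plain piperidin-1-yl or morpholin-4-yl would stand at this place also remains open.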